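Phenyl for methyl on the core: a substitution to test

The source may report more compounds than this note shows. Statements on the series, on what has been measured and on what is new or still open speak of the compounds shown alone.

Measured so far in an assay with 3-hydroxy-3-methylglutaryl-coenzyme A reductase (Rattus norvegicus) as the target, using microsomes; on this read-out higher numbers stand for weaker inhibition and lower numbers for stronger inhibition:
compound 1 `CC(C)c1nn(-c2ccccc2)c(-c2ccc(F)cc2)c1/C=C/[C@@H](O)C[C@@H](O)CC(=O)O` gives 7.2 nM
compound 2 `CC(C)c1nn(-c2cnccn2)c(-c2ccc(F)cc2)c1/C=C/[C@@H](O)C[C@@H](O)CC(=O)O` gives 6.6 nM
compound 3 `Cc1cc(-c2ccc(F)cc2)c(/C=C/[C@@H](O)C[C@@H](O)CC(=O)O)c(C(C)C)n1` gives 7.7 nM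

Compound 3 has the highest of the three numbers, but its gaps to compound 1 and to compound 2 are within the scatter, so the three cannot be told apart in this assay. Compound 4 `CC(C)c1nc(-c2ccccc2)cc(-c2ccc(F)cc2)c1/C=C/[C@@H](O)C[C@@H](O)CC(=O)O` is not yet measured; it differs from compound 3 by phenyl in place of methyl on an aromatic carbon, on an aromatic carbon of a six-membered aromatic ring with 1 nitrogen, next to the ring nitrogen. For the measured compounds named here, only one measured step exists, a 1.1-fold lower number from compound 1 to compound 2 (0.04 log units; within the scatter), an aryl exchange on an aromatic nitrogen of a different core; it bears on the present change only loosely, yet it shows an aryl swap on the core leaving this assay flat. No step beyond the scatter is therefore expected. Compound 4 is estimated at 7.5 nM (range 2.5 nM to 25 nM), meaning an expected step of a 1.0-fold lower number from compound 3 to compound 4 (0.01 log units; within the scatter).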

Compound 4, half-maximal inhibitory concentration: 2 nM
Estimate against measurement, compound 4: 3.8-fold (0.57 log units) above, outside the stated range (below it).
By their numbers in this assay, from the lowest: compound 4; then compounds 2, 1 and 3 (each within the scatter of the next).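

In this assay, for the compounds shown here, phenyl in place of methyl on an aromatic carbon, next to the ring nitrogen, gives a 3.9-fold lower number from compound 3 to compound 4 (0.59 log units; beyond the scatter) and is the first step beyond the scatter. This position therefore responds to the group it carries, unlike the aryl exchange on an aromatic nitrogen of a different core, which gave a 1.1-fold lower number from compound 1 to compound 2 (0.04 log units; within the scatter) in the same assay. No measurement at hand speaks to what lies behind the lower number. Open, as far as these compounds go, is whether the step needs an aromatic ring: a cyclohexyl ring, an ethyl chain or an amine at this position could fall with either methyl or phenyl.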